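A few compounds are considered here, and "the series" means these few. Any claim that something is new, unique, unknown or untested is made for them only; others in the source may bear on it.

Measured in a functional assay on CHO cells with adenosine receptor A1 (Homo sapiens) as the target, read by cAMP accumulation and immunoassay, with a stated time of 6 min, tested at 0.01 uM; on this read-out lower numbers stand for a stronger effect and higher numbers for a weaker effect at the one concentration tested:

compound 1, `Nc1scc(CN2CCN(c3cccc(Cl)c3Cl)CC2)c1C(=O)c1ccc(Cl)cc1`: 1%
compound 2, `Nc1scc(CN2CCN(c3ccc(Cl)cc3F)CC2)c1C(=O)c1ccc(Cl)cc1`: -9.2%
compound 3, `Nc1scc(CN2CCN(c3ccccc3C(F)(F)F)CC2)c1C(=O)c1ccc(Cl)cc1`: 0%

Among the three numbers, the value of compound 2 is the lowest, but only one of its steps is beyond the scatter: a number 10.2 percentage points lower from compound 1 to compound 2 (beyond the scatter), a modest step. Against compound 3 the picture is flat, a number 9.2 percentage points higher from compound 2 to compound 3 (within the scatter), and compound 1 and compound 3 are likewise indistinguishable, a number 1 percentage points lower from compound 1 to compound 3 (within the scatter). All three compounds share one core and differ only in the aryl group on the ring nitrogen, and all three read close to zero in this assay .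

Compound 4, `Nc1scc(CN2CCN(c3ccc(Cl)c(C(F)(F)F)c3)CC2)c1C(=O)c1ccc(Cl)cc1`, is the next member of this set; compared with compound 2 the change is 4-chloro-3-(trifluoromethyl)phenyl in place of 4-chloro-2-fluorophenyl on an amine nitrogen in a ring. The three measured steps all exchange one substituted phenyl for another at the same position, and none of them moved the read-out by more than a modest amount. The expected step is therefore small, a number 6.2 percentage points higher from compound 2 to compound 4 (within the scatter), with no direction beyond the scatter. The estimate for compound 4 in this assay is -3%, within the range -14% to 8%.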

Compound 4, a percentage reported as activity, at one concentration (the size of the read-out at that concentration, not a potency): -2.5%
The estimate for compound 4 lay 0.5 percentage points below the measured number; the range from low to high includes it.
By their numbers in this assay, from the lowest: compounds 2, 4, 3 and 1 (each within the scatter of the next, the first and the last beyond it).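

In this assay, 4-chloro-3-(trifluoromethyl)phenyl on the amine nitrogen in the ring is not separated from any of the three earlier aryl groups: a number 6.7 percentage points higher from compound 2 to compound 4 (within the scatter); a number 2.5 percentage points lower from compound 3 to compound 4 (within the scatter); and a number 3.5 percentage points lower from compound 1 to compound 4 (within the scatter). Among the compounds shown here, this position therefore also accepts chlorine and trifluoromethyl together on one phenyl ring, a combination absent from the earlier compounds, and compound 4 lies within the scatter of both compound 1 and compound 2, the one pair separated beyond it. Nothing available explains why the read-out stays so flat across these aryl groups.

All four groups are phenyl rings carrying halogen or trifluoromethyl substituents. Still open, from the compounds shown here alone, is how the read-out responds to a phenyl ring bearing an amine or a carboxylic acid, or to a pyridine ring in place of the phenyl.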